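From Carboxylic Acid to Ethyl Ester on One Core

This account rests on a few compounds, and the source may have more. Where it says the series, first, only, none or still open, it means among the compounds named here.

Compound 1 `CCCSc1nc(Cl)c2c(n1)N(Cc1ccccc1)C(C(=O)O)N2` has been measured in a functional assay on A549 cells (Homo sapiens) for antiproliferative activity, read by MTT assay, with a stated time of 72 h (a lower number here means a stronger inhibitor, a higher number a weaker inhibitor), where compound 1 gives 10700 nM. Among the three measured compounds this is the second highest number. Compound 3 `CCCSc1nc(Cl)c2c(n1)N(CC1CCCCC1)C(C(=O)N1CCN(C)CC1)N2` gives 13200 nM, which lies within the scatter of the value of compound 1, and compound 2 `CCCSc1nc(Cl)c2c(n1)N(Cc1cccs1)C(C(=O)N1CCN(C)CC1)N2` gives 6420 nM, also within the scatter of compound 1. Among the measured compounds shown here, the only step measured between two compounds that differ in a single place is a 2.1-fold higher number from compound 2 to compound 3 (0.31 log units; beyond the scatter); it concerns the group on the saturated chain carbon bound to a nitrogen on an aromatic ring and leaves the carbonyl end of the molecule untouched.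

Compound 4 `CCCSc1nc(Cl)c2c(n1)N(Cc1ccccc1)C(C(=O)OCC)N2` differs from compound 1 by ethyl in place of hydrogen on an oxygen next to a carbonyl group. For the measured compounds named here, no measured step bears on this change: compounds 2 and 3 carry an amide rather than an ester or acid at that position and also differ from compound 1 elsewhere, so their values cannot be read across. With nothing to lean on, a change in this assay of no more than modest size is expected for compound 4, in either direction. Compound 4 is estimated at 7000 nM, with a range from 2500 nM to 20000 nM. The expected step is a 1.5-fold lower number from compound 1 to compound 4 (0.18 log units; within the scatter).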

Compound 4, half-maximal inhibitory concentration: 13800 nM
Compound 4: the middle estimate sits 2.0-fold (0.29 log units) below what was measured, and the stated range covers the measured number.
By their numbers in this assay, from the lowest: compounds 2, 1, 3 and 4 (each within the scatter of the next, the first and the last beyond it).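

Among the compounds shown here, the step from the carboxylic acid to its ethyl ester gives the first direct reading at this position: in this assay the change of ethyl in place of hydrogen on an oxygen next to a carbonyl group (a 1.3-fold higher number from compound 1 to compound 4 (0.11 log units; within the scatter)) does not separate the two compounds. On the core of compound 1, then, carboxy and ethoxycarbonyl cannot be told apart in this read-out, even though the ester adds 2 heavy atoms and replaces the hydrogen on that oxygen. For the compounds shown here, the earlier compounds could not show this, since their only single-place step concerned the group at the other end of the molecule, and nothing at hand explains the present outcome.

On these data alone, whether this holds for other groups on the same oxygen, such as methyl or a longer chain, or for a primary amide at the carbonyl, remains open, as does how the amide of compound 2 and compound 3 would compare on the core of compound 1. As far as these compounds go, it is equally open whether the exchange of acid for ethyl ester would read the same with thiophen-2-yl or cyclohexyl in the other variable place.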